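Swapping a Dichlorophenyl for a Methoxyphenyl on the Sulfonyl

The source may hold more compounds than are shown below. What is called first, only, known or untested is meant among the compounds shown, and "the series" means these compounds.

Of the compounds shown here, three sharing one core have been measured in a functional assay on DLD-1 cells (Homo sapiens) for antiproliferative activity, read by CellTiter-Glo, with a stated time of 72 h; a higher number here means a weaker inhibitor, a lower number a stronger inhibitor. Compound 1 `COc1ccc(S(=O)(=O)N2CCC(N3CCC(C)CC3)CC2)cc1OC` gives 138 nM in this assay, compound 2 `CC1CCN(C2CCN(S(=O)(=O)c3ccc(F)cc3F)CC2)CC1` gives 102 nM, and compound 3 `CC1CCN(C2CCN(S(=O)(=O)c3ccc(Cl)c(Cl)c3)CC2)CC1` gives 2.9 nM. Compound 3 therefore stands at the lowest number of the three, with compound 2 its nearest neighbour and compound 1 the furthest away, both gaps beyond the scatter.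

Within the data shown here, the one step measured so far is a 35-fold lower number from compound 2 to compound 3 (1.55 log units; beyond the scatter). That step shows how much the group on the sulfonyl sulfur can move the number, with the 3,4-dichlorophenyl giving the lowest value seen.

Compound 4 `COc1cccc(S(=O)(=O)N2CCC(N3CCC(C)CC3)CC2)c1` has not yet been measured. Compared with compound 3, it differs in one place: 3-methoxyphenyl in place of 3,4-dichlorophenyl on a sulfonyl sulfur. Among the measured compounds shown here, no measured step covers exactly this swap, but compound 1, which carries a 3,4-dimethoxyphenyl on the same sulfur, sits far from compound 3, and compound 2 shows the same direction. The expectation is therefore a clear move to a higher number, estimated as a 34-fold higher number from compound 3 to compound 4 (1.54 log units; beyond the scatter). For compound 4 the expected value in this assay is 100 nM, with a range from 30 nM to 350 nM.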

Compound 4, half-maximal inhibitory concentration: > 5000 nM
Compound 4: only a limit was reported; the forecaster's own chance of this, stated with the estimate: 2%; at least 50-fold (1.69 log units) between middle value and limit.
By their numbers in this assay, from the lowest: compound 3; then compounds 2 and 1 (each within the scatter of the next). At a limit, above all of these: compound 4.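

The value for compound 4 is a limit and not a number: the limit of > 5000 nM in this assay, at which 1 of the 4 values shown sits. Even so, the smallest change in the set, hydrogen in place of methoxy on an aromatic carbon, gives an at least 36-fold higher number from compound 1 to compound 4 (1.55 log units; beyond the scatter), so the 3,4-dimethoxyphenyl and the 3-methoxyphenyl do not behave alike on the sulfonyl sulfur even though they differ by a single methoxy. Swapping the whole substituted ring on that sulfur gives an at least 1700-fold higher number from compound 3 to compound 4 (3.23 log units; beyond the scatter) and an at least 49-fold higher number from compound 2 to compound 4 (1.69 log units; beyond the scatter), which shows that this position can do more than shift the reading within a measurable range, since here the change carries it all the way to the limit of this assay.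

The compounds shown do not tell why removing one methoxy has such a large effect, and the true size of all three steps stays unknown while compound 4 has only a limit. They also leave open how an unsubstituted phenyl, or a phenyl carrying an amine or a carboxylic acid, would read on the same sulfonyl sulfur with the shared core unchanged.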